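The source may report more compounds than this note shows. Statements on the series, on what has been measured and on what is new or still open speak of the compounds shown alone.

Measured so far:
compound 1 `CC(C)(C)c1ccc(Cn2nc(-c3ccccc3)cc2C(=O)NN[C@@H]2OC[C@@H](O)[C@H](O)[C@H]2O)cc1` — 15200 nM
compound 2 `O=C(NN[C@@H]1O[C@H](CO)[C@@H](O)[C@H](O)[C@H]1O)c1cc(-c2ccc(Cl)cc2)nn1Cc1ccc(Cl)nc1` — 35000 nM

Both numbers come from a functional assay on A549 cells (Homo sapiens) for inhibition, read by sulforhodamine B assay, with a stated time of 48 h; a higher number here means a weaker inhibitor, a lower number a stronger inhibitor. Compound 1 holds the lower of the two; compound 2 sits beyond the scatter above it. Among the measured compounds shown here, no single-change step between measured compounds is available, so the size of any one modification is untested.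

Compound 3 `COc1ccc(-c2cc(C(=O)NN[C@@H]3OC[C@@H](O)[C@H](O)[C@H]3O)n(Cc3ccc(C(C)(C)C)cc3)n2)cc1` is the next candidate. It differs from compound 1 by methoxy in place of hydrogen on an aromatic carbon. With nothing measured for this kind of change, the step of a 1.2-fold lower number from compound 1 to compound 3 (0.07 log units; within the scatter) is expected to stay within the scatter, with no direction assumed. Compound 3 is therefore estimated at 13000 nM, ranging from 5500 nM to 32000 nM.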

Compound 3, half-maximal inhibitory concentration: 24900 nM
Estimate against measurement, compound 3: 1.9-fold (0.28 log units) below; low and high end bracket the measured number.
By their numbers in this assay, from the lowest: compounds 1, 3 and 2 (each within the scatter of the next, the first and the last beyond it).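

In this assay, among the compounds shown here, the change from phenyl to 4-methoxyphenyl gives a 1.6-fold higher number from compound 1 to compound 3 (0.21 log units; within the scatter) and is the first single-change step. This aromatic carbon, para to a large group, therefore accepts methoxy in place of hydrogen with no change that can be told from the scatter. That reading rests on one pair and one substituent. Going by these compounds, whether an amine, a carboxylic acid or a longer chain such as ethoxy at this carbon would also stay within the scatter of compound 1 remains open. No measured evidence bears on this result.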